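This account rests on a few compounds, and the source may have more. Where it says the series, first, only, none or still open, it means among the compounds named here.

Values in an ADME assay on MT4 cells (Homo sapiens) for cytotoxicity, read by MTT assay (on this read-out lower numbers stand for higher toxicity in this test and higher numbers for lower toxicity in this test), follow
compound 1 (`Cc1cc(C)cc(S(=O)(=O)c2c(C(=O)NC(C)C(=O)NCCn3c(C)cnc3[N+](=O)[O-])[nH]c3ccc(Cl)cc23)c1`) gives 16000 nM
compound 2 (`Cc1cc(C)cc(S(=O)(=O)c2c(C(=O)Nc3ccnc(C#N)c3)[nH]c3ccc(Cl)cc23)c1`) gives 6840 nM
compound 3 (`Cc1cc(C)cc(S(=O)(=O)c2c(C(=O)NCC(=O)NCCn3c(C)cnc3[N+](=O)[O-])[nH]c3ccc(Cl)cc23)c1`) gives 24500 nM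

Compound 1 (16000 nM) lies within the scatter of compound 3, while compound 2 gives a lower number (6840 nM). Compound 4 (`Cc1cc(C)cc(S(=O)(=O)c2c(C(=O)NC(C)C(=O)NC(C)c3ccccc3F)[nH]c3ccc(Cl)cc23)c1`) has not yet been measured. It differs from compound 1 in one group (a group of 9 heavy atoms (8 carbon, 1 fluorine; one six-membered aromatic ring of carbon only) in place of a group of 11 heavy atoms (6 carbon, 3 nitrogen, 2 oxygen; one five-membered aromatic ring with 2 hetero atoms), on an amide-type nitrogen). Among the compounds with values here, the only measured step (a 1.5-fold higher number from compound 1 to compound 3 (0.19 log units; within the scatter)) exchanges methyl for hydrogen on a saturated chain carbon, so it does not cover this replacement. In this assay no step beyond the scatter is therefore expected, in either direction, and the uncertainty is wide. The expected step is small (a 1.1-fold lower number from compound 1 to compound 4 (0.06 log units; within the scatter)). Compound 4 is estimated at 14000 nM (expected range 4500 nM to 45000 nM).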

Compound 4, half-maximal cytotoxic concentration: 15200 nM
Estimate against measurement, compound 4: 1.1-fold (0.04 log units) below; measured number inside the range.
By their numbers in this assay, from the lowest: compound 2; then compounds 4, 1 and 3 (each within the scatter of the next).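

Until now only a methyl on the saturated chain carbon had been varied. Compound 4 changes the whole group on the amide-type nitrogen: a five-membered aromatic ring group with hydrogen-bond acceptors gives way to 1-(2-fluorophenyl)ethyl, which has none, and this assay shows a 1.1-fold lower number from compound 1 to compound 4 (0.02 log units; within the scatter). Nothing measured here explains why so large an exchange leaves the number within the scatter.

From the compounds shown here alone, what an amine or a carboxylic acid would give on this amide-type nitrogen remains open. So does what a plain 1-phenylethyl group would give.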